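This account rests on a few compounds, and the source may have more. Where it says the series, first, only, none or still open, it means among the compounds named here.

Measured compounds:
compound 1 `C[C@H](NC(=O)c1cccc(-c2cncc(C(=O)NC3CC3)c2)c1)C(=O)Nc1ccc(Cl)c(C(F)(F)F)c1`, 15100 nM
compound 2 `CC(=O)Nc1ccc(-c2cccc(C(=O)N[C@@H](C)C(=O)Nc3ccc(Cl)c(C(F)(F)F)c3)c2)cn1`, 42800 nM
compound 3 `CC(=O)Nc1ccc(-c2ccc(C(=O)N[C@@H](C)C(=O)Nc3ccc(Cl)c(C(F)(F)F)c3)cc2)cn1`, 107000 nM

All three were read in a functional assay on K562 cells (Homo sapiens) for inhibition, read by MTT assay, with a stated time of 48 h; on this read-out lower numbers stand for stronger inhibition and higher numbers for weaker inhibition. Compound 1 gives 15100 nM, compound 2 gives 42800 nM and compound 3 gives 107000 nM, the highest number of the three. Compounds 2 and 3 share the same atoms joined differently; the difference between the two cores is not broken down here.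

One change is measured once: 5-(cyclopropylcarbamoyl)pyridin-3-yl in place of 6-acetamidopyridin-3-yl on an aromatic carbon, giving a 2.8-fold lower number from compound 2 to compound 1 (0.45 log units; beyond the scatter). The same kind of change is now considered on the core of compound 3, yielding compound 4 `C[C@H](NC(=O)c1ccc(-c2cncc(C(=O)NC3CC3)c2)cc1)C(=O)Nc1ccc(Cl)c(C(F)(F)F)c1`, unmeasured in this assay: 5-(cyclopropylcarbamoyl)pyridin-3-yl in place of 6-acetamidopyridin-3-yl on an aromatic carbon. The two places are not identical in their surroundings: in compound 2 the change is made meta to a large group, in compound 3 para to a large group, so the step is transferred from one core to another.

The expectation for compound 4 rests on the measured step of a 2.8-fold lower number from compound 2 to compound 1 (0.45 log units; beyond the scatter) applied to compound 3 and its value 107000 nM. A step of about the same size, a 2.7-fold lower number from compound 3 to compound 4 (0.43 log units; beyond the scatter), is expected, with widened uncertainty because the core differs. Compound 4 is therefore estimated at 40000 nM, within 15000 nM to 100000 nM.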

Compound 4, half-maximal inhibitory concentration: 396000 nM
For compound 4 the middle estimate is 9.9-fold (1.00 log units) below the measured one; measured number above the stated range.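

In this assay, the change to 5-(cyclopropylcarbamoyl)pyridin-3-yl from 6-acetamidopyridin-3-yl, made para to a large group, gives a 3.7-fold higher number from compound 3 to compound 4 (0.57 log units; beyond the scatter), and this runs against the direction seen on the other core: the same change on two cores in this assay, a 2.8-fold lower number (0.45 log units; beyond the scatter) from compound 2 to compound 1 and a 3.7-fold higher number (0.57 log units; beyond the scatter) from compound 3 to compound 4, 10-fold (1.02 log units) apart, beyond the scatter of two such steps

In this series, then, the effect of this change does not carry from one core to the other, and even its direction depends on the core it is made on. The result rests on a single pair per core, so it shows that the two steps differ but not why, and it sets no rule for other groups or other cores.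

Still open, as far as these compounds go, is how an amine or a carboxylic acid in place of the cyclopropylcarbamoyl group would behave on each of the two cores. Equally open, from the compounds shown here alone, is whether a longer chain in place of the cyclopropyl ring would keep the same opposite steps.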